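A Methyl Added to the Ester Chain of Compound 2

This account rests on a few compounds, and the source may have more. Where it says the series, first, only, none or still open, it means among the compounds named here.

In a functional assay on the whole organism for antagonist activity, with Mus musculus as the target, in the maximal electroshock model (a lower number here means that less compound is needed, a higher number that more compound is needed for the effect), compound 1 (`CCOC(=O)NC1=NC(c2ccccc2)CN1C`) gives 78 mg/kg and compound 2 (`COC(=O)NC1=NC(c2ccccc2Cl)CN1C`) gives 28 mg/kg as the lower of the two numbers. Compound 3 (`CCOC(=O)NC1=NC(c2ccccc2Cl)CN1C`) has not yet been measured. It differs from compound 2 by one small change (methyl in place of hydrogen on a saturated chain carbon bound to an oxygen next to a carbonyl group): methyl in place of hydrogen on a saturated chain carbon bound to an oxygen next to a carbonyl group, so methoxycarbonyl becomes ethoxycarbonyl. For the measured compounds named here, no measured pair shows this change alone, so no step beyond the scatter is expected in this assay. The estimate is a 1.1-fold higher number from compound 2 to compound 3 (0.03 log units; within the scatter) and would lie within the scatter. Compound 3 is expected at 30 mg/kg with an estimated range from 14 mg/kg to 62 mg/kg around that value.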

Compound 3, dose for half-maximal effect: 28 mg/kg
Compound 3: the middle estimate sits 1.1-fold (0.03 log units) above what was measured, and the stated range covers the measured number.
By their numbers in this assay, from the lowest: compounds 2 and 3 (each within the scatter of the next); then compound 1.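

In this assay, going from methoxycarbonyl to ethoxycarbonyl gives no change at the digits printed from compound 2 to compound 3 (within the scatter), so the added methyl on this saturated chain carbon leaves the dose needed unaffected. Compound 3 also isolates the other change: chloro in place of hydrogen on an aromatic carbon gives a 2.8-fold lower number from compound 1 to compound 3 (0.44 log units; beyond the scatter), a modest step that needs less compound. Nothing measured here gives a reason for either step. Going by these compounds, whether a longer chain, such as propyl or butyl, would keep the number stays open, as does whether fluoro or methoxy could stand in for chloro.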